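This account rests on a few compounds, and the source may have more. Where it says the series, first, only, none or still open, it means among the compounds named here.

Compound 2 `CN1CC=C(c2c(O)cc(O)c3c(=O)cc(-c4ccc(Sc5nc6ccccc6n5C)cc4Cl)oc23)CC1` stands highest of the two numbers recorded in a functional assay on HCT-116 cells (Homo sapiens) for antiproliferative activity, read by luminescence, with a stated time of 72 h (on this read-out higher numbers stand for weaker inhibition and lower numbers for stronger inhibition), where compound 2 gives 181 nM. Its nearest neighbour is compound 1 `CN1CC=C(c2c(O)cc(O)c3c(=O)cc(-c4ccc(Sc5nc6ccccc6[nH]5)cc4Cl)oc23)CC1`, which in this assay gives 170 nM; the step of a 1.1-fold higher number from compound 1 to compound 2 (0.03 log units; within the scatter) lies within the scatter, so the two compounds cannot be ordered on this read-out.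

Compound 3 `CN1CC=C(c2c(O)cc(O)c3c(=O)cc(-c4ccc(Sc5nc6ccccc6n5C)cc4)oc23)CC1` differs from compound 2 in one place: hydrogen in place of chloro on an aromatic carbon. Among the measured compounds shown here, no measured step bears on this change. For the measured compounds named here, the single step so far measured, a 1.1-fold higher number from compound 1 to compound 2 (0.03 log units; within the scatter), concerns methyl in place of hydrogen on an aromatic nitrogen and is silent on the chloro, which both measured compounds carry. The data therefore give no direction for the removal of chloro, and the account can only say that nothing in the measured pair argues for a step beyond the scatter in either direction. Going by the values given here, on that basis compound 3 is expected to give 220 nM in this assay, within 60 nM to 800 nM, the expected step being a 1.2-fold higher number from compound 2 to compound 3 (0.08 log units; within the scatter), with the range kept wide because no measured step speaks to this change.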

Compound 3, half-maximal inhibitory concentration: 219 nM
Beside the measured number, compound 3's estimate is 1.0-fold (0.00 log units) above it; measured number inside the range.
By their numbers in this assay, from the lowest: compounds 1, 2 and 3 (each within the scatter of the next).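

With chloro replaced by hydrogen on the six-membered aromatic ring of carbon only, at the place ortho to a large group and meta to the (1-methyl-1H-benzimidazol-2-yl)sulfanyl group, this assay gives a 1.2-fold higher number from compound 2 to compound 3 (0.08 log units; within the scatter). Among the compounds shown here, this is the first step that bears on this position, and it shows that, with the methyl on the aromatic nitrogen in place, chloro and hydrogen at this carbon cannot be told apart on this read-out, so the chloro carried by compound 1 and compound 2 is not needed to keep the number within the scatter in this pair. The data on hand offer no measurement that would explain this outcome.

The compounds shown leave open whether the same exchange would also stay within the scatter in the setting of compound 1, where the aromatic nitrogen carries hydrogen rather than methyl. They also leave open what this carbon would tolerate beyond chloro and hydrogen, for instance a methoxy group, an amine or a carboxylic acid, any of which could move the number in either direction.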